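The compounds below may be only part of what the source reports. "The series", "measured", "known", "first", "only" and "open" are said of these compounds alone.

- Compound 1 `COc1ccc(C2=C(c3cc(OC)c(OC)c(OC)c3)C(=O)CC2O)cc1O` gives < 1 ug/mL as its reading
- Compound 2 `COc1ccc(C2=C(c3cc(OC)c(OC)c(OC)c3)C(=O)CC2O)cc1` gives 3.38 ug/mL as its reading

Both compounds were tested in an ADME assay on PA-1 cells (Homo sapiens) for cytotoxicity, read by MTT assay, with a stated time of 72 h (a higher number here means a weaker inhibitor, a lower number a stronger inhibitor), and no other test is available. In this assay compound 1 gives < 1 ug/mL as its reading, which is a limit and not a number. Its exact position is therefore unknown.

Compound 3 `COc1ccc(C2=C(c3cc(OC)c(OC)c(OC)c3)C(=O)CC2O[SiH2]C(C)(C)C)cc1O` keeps the core of compound 1 and differs in one place: a group of 5 heavy atoms (4 carbon, 1 silicon; no ring) in place of a hydrogen atom, on an oxygen on a saturated carbon on an oxygen on a saturated carbon. Going by the values given here, no measured compound shows what a change on this oxygen does.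

Among the compounds with values here, the only measured step is an at least 3.3-fold higher number from compound 1 to compound 2 (0.52 log units; beyond the scatter) with hydrogen in place of hydroxy on an aromatic carbon. That change to compound 2 lies elsewhere in the molecule, so it is only a rough guide. It does show that a single change to compound 1 can move the number beyond the scatter.

A modest rise is expected, with wide uncertainty, and the expected step is an at least 2.0-fold higher number from compound 1 to compound 3 (0.30 log units; that floor lies within the scatter) in this estimate. Compound 3 is estimated at 2 ug/mL with an expected range from 0.4 ug/mL to 10 ug/mL in this assay when measured.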

Compound 3, half-maximal inhibitory concentration: 14 ug/mL
Estimate against measurement, compound 3: 7.0-fold (0.85 log units) below; measured number above the stated range.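

In this assay, going by these compounds alone, compound 1 and compound 2 both keep the hydrogen on the oxygen on the saturated carbon, so compound 3 is the first to show what a change there does: the group of 5 heavy atoms (4 carbon, 1 silicon; no ring) in place of that hydrogen gives an at least 14-fold higher number from compound 1 to compound 3 (1.14 log units; beyond the scatter). This position is therefore sensitive to this change, which counts as large, while the change on the aromatic carbon gave an at least 3.3-fold higher number from compound 1 to compound 2 (0.52 log units; beyond the scatter), which counts as at least modest. The full size of the new step stays unknown because compound 1 stands at a limit and not at a number: the limit of < 1 ug/mL in this assay, at which 1 of the 3 values shown sits.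

As far as these compounds go, what remains open is whether the loss follows from removing the hydrogen from this oxygen or from the particular silicon-bearing group that enters. A small methyl group on the same oxygen, or an amine in place of the hydroxy on the saturated carbon, would help separate these two readings, since a single substituent at this position cannot show a trend.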